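The source may report more compounds than this note shows. Statements on the series, on what has been measured and on what is new or still open speak of the compounds shown alone.

Working notes on the series.

Compound 1, `CC(C)=CCOc1c(C)c(C)c2c(c1C)CCC(C)(COc1ccc(/C=C3\SC(=O)NC3=O)cc1C)O2`, is the reference point here. In a functional assay on MCF7 cells (Homo sapiens), tested at 2.5 uM (on this read-out higher numbers stand for a weaker effect at the one concentration tested and lower numbers for a stronger effect), compound 1 gives 89%, the lower of the two numbers in hand. Going by the values given here, the other measured member, compound 2, `Cc1c(C)c2c(c(C)c1OC(=O)CCC(=O)O)CCC(C)(COc1ccc(/C=C3\SC(=O)NC3=O)cc1)O2`, gives 115% in this assay, a gap beyond the scatter; the two differ in more than one place, so the pair shows only that compound 1 reads lower.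

Compound 3, `CC(C)=CCOc1c(C)c(C)c2c(c1C)CCC(C)(COc1ccc(/C=C3\SC(=O)NC3=O)cc1)O2`, differs from compound 1 in one place: hydrogen in place of methyl on an aromatic carbon. The site is an aromatic carbon of a six-membered aromatic ring of carbon only, ortho to a large group and meta to a group of 8 heavy atoms. Nothing measured in the series isolates this change, so no step size is known for it.

Expectation: the removal of a single methyl is judged unlikely to move the read-out beyond the scatter, so compound 3 is expected to give 92% in this assay, within 75% to 110%. The expected step of a number 3 percentage points higher from compound 1 to compound 3 (within the scatter) is therefore essentially none beyond the scatter.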

Compound 3, a percentage reported as activity, at one concentration (the size of the read-out at that concentration, not a potency): 76%
For compound 3 the middle estimate is 16 percentage points above the measured one; the measured number falls inside the stated range.
By their numbers in this assay, from the lowest: compound 3; then compound 1; then compound 2.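

In this assay hydrogen in place of methyl on this aromatic carbon gives a number 13 percentage points lower from compound 1 to compound 3 (beyond the scatter) and so a stronger effect at the one concentration tested, which shows that this single methyl is not silent at this position. On an oxygen on an aromatic ring, 3-methylbut-2-en-1-yl in place of (2-carboxyethyl)carbonyl gives a number 39 percentage points lower from compound 2 to compound 3 (beyond the scatter) as the larger of the two steps, a size no single-place comparison had shown before. Nothing in hand explains either step.

As far as these compounds go, whether ethyl, methoxy or fluorine on the same aromatic carbon would read differently from hydrogen and methyl remains open, as does the outcome of an amine or a longer chain on the oxygen. Both steps rest on one concentration, so they say nothing about potency.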